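One Fluorine Removed from the Side Chain of Compound 2

The compounds below may be only part of what the source reports. "The series", "measured", "known", "first", "only" and "open" are said of these compounds alone.

Of the compounds shown here, three sharing one core have been measured in a functional assay on HL-60 cells (Homo sapiens) for cytotoxicity, read by WST assay, with a stated time of 48 h; a higher number here means a weaker inhibitor, a lower number a stronger inhibitor. Compound 2 `COc1cc(C(c2ccc(O)c(OC)c2)[C@@H](C)[C@H](C)CF)ccc1O` gives 32000 nM. Compound 1 `COC[C@H](C(C)C)C(c1ccc(O)c(OC)c1)c1ccc(O)c(OC)c1` gives 72000 nM, and compound 3 `COc1ccc(C(c2ccc(OC)c(OC)c2)[C@H](C)[C@@H](C)CO)cc1OC` gives 47000 nM. Compound 2 thus stands at the low end of the three numbers: its separation from compound 1 is beyond the scatter, while the value of compound 3 lies within the scatter of compound 2. The one single-site step among these compounds is a 2.3-fold lower number from compound 1 to compound 2 (0.35 log units; beyond the scatter), a modest change that exchanged the whole branched chain.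

Compound 4 `COc1cc(C(c2ccc(O)c(OC)c2)[C@@H](C)C(C)C)ccc1O` is not yet measured. It differs from compound 2 in one place: hydrogen in place of fluoro on a saturated chain carbon, four bonds along the chain from two aromatic carbons. Among the measured compounds shown here, no measured step removes a fluorine alone, so the step from compound 1 to compound 2 is the only guide, and it spoke for the chain region as a whole rather than for the fluorine. All three measured chains, differing in their branching and end groups, gave numbers within a narrow band. A step of no more than the scatter is therefore expected in this assay, in either direction. The estimated step is a 1.3-fold higher number from compound 2 to compound 4 (0.10 log units; within the scatter). Compound 4 is expected to give 40000 nM, with a range from 15000 nM to 100000 nM.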

Compound 4, half-maximal inhibitory concentration: 20000 nM
Compound 4: middle estimate off by 2.0-fold (0.30 log units), on the high side; the measured number falls inside the stated range.
By their numbers in this assay, from the lowest: compounds 4, 2, 3 and 1 (each within the scatter of the next, the first and the last beyond it).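

In this assay, the step that removes the fluorine alone, hydrogen in place of fluoro on a saturated chain carbon, four bonds along the chain from two aromatic carbons, reads a 1.6-fold lower number from compound 2 to compound 4 (0.20 log units; within the scatter), so fluoro and hydrogen cannot be told apart at this place in this assay. The larger exchange, 1,2-dimethylpropyl in place of 1-(methoxymethyl)-2-methylpropyl on a saturated chain carbon bound to two aromatic carbons, reads a 3.6-fold lower number from compound 1 to compound 4 (0.56 log units; beyond the scatter), which shows that a modest step beyond the scatter can be reached by changing the whole branched chain, while the fluorine by itself does not give one. No independent measurement is available to explain either step.

The compounds shown leave open whether an amine or a carboxylic acid on this same saturated chain carbon, or a longer chain in place of 1,2-dimethylpropyl, would give a step larger than these modest ones. They also leave open whether hydrogen and fluoro would remain this hard to separate in a different cell line.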